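Swapping Trifluoromethyl for Chloro on the Shared Core

A few compounds are considered here, and "the series" means these few. Any claim that something is new, unique, unknown or untested is made for them only; others in the source may bear on it.

Compound 3 `Oc1ccc(C(F)(F)F)cc1-c1nc(N[C@H]2CCNC2)c2ccccc2n1` is one of three measured analogues that share a core and differ only in the group on one aromatic carbon. In an assay on isolated protein for inhibition of serine/threonine-protein kinase Chk2 (Homo sapiens) (a higher number here means a weaker inhibitor, a lower number a stronger inhibitor), compound 3 gives 201 nM, the second highest of the three numbers. Its nearest neighbour is compound 1 `Cc1ccc(O)c(-c2nc(N[C@H]3CCNC3)c3ccccc3n2)c1`, which in this assay gives 92 nM; the step of a 2.2-fold higher number from compound 1 to compound 3 (0.34 log units; beyond the scatter) is modest. Furthest away is compound 2 `CC(C)c1ccc(O)c(-c2nc(N[C@H]3CCNC3)c3ccccc3n2)c1`, which in this assay gives 1700 nM, so that an 8.5-fold lower number from compound 2 to compound 3 (0.93 log units; beyond the scatter) is a modest fall, while an 18-fold higher number from compound 1 to compound 2 (1.27 log units; beyond the scatter) is a large rise. Compound 4 `Oc1ccc(Cl)cc1-c1nc(N[C@H]2CCNC2)c2ccccc2n1` brings the next change: chloro in place of trifluoromethyl on an aromatic carbon. Both measured steps that touch this carbon show that the group there moves the number beyond the scatter, and the lowest number came with methyl in compound 1. A modest fall from compound 3 is therefore expected, a 1.8-fold lower number from compound 3 to compound 4 (0.26 log units; within the scatter). For compound 4 the estimate in this assay is 110 nM, with a range from 40 nM to 300 nM.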

Compound 4, half-maximal inhibitory concentration: 70 nM
The estimate for compound 4 lay 1.6-fold (0.20 log units) above the measured number, and the stated range covers the measured number.
By their numbers in this assay, from the lowest: compounds 4 and 1 (each within the scatter of the next); then compound 3; then compound 2.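

Chloro is the first group on this aromatic carbon to sit level with methyl in this assay: the step is a 1.3-fold lower number from compound 1 to compound 4 (0.12 log units; within the scatter), so these two groups cannot be ranked. Against the other two groups the change matters far more, with a 2.9-fold lower number from compound 3 to compound 4 (0.46 log units; beyond the scatter) and, the largest step in this small set, a 24-fold lower number from compound 2 to compound 4 (1.39 log units; beyond the scatter). Here the one heavy atom of chloro in place of the four of trifluoromethyl goes with a lower number, but no measurement shown here explains the difference.

Still open, on these data alone, is whether another halogen, such as fluoro or bromo, or a group such as methoxy or an amine, would stay level with chloro and methyl at this carbon. Also open, as far as these compounds go, is whether this order of groups would hold if the hydroxy group or the rest of the shared core were changed.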